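The source may hold more compounds than are shown below. What is called first, only, known or untested is meant among the compounds shown, and "the series" means these compounds.

Measured compounds:
Compound 1 `N/C(=N\NC(=S)N1CCOCC1)c1ccccn1`: 56.3%
Compound 2 `N/C(=N\NC(=S)N1CCSCC1)c1ccccn1`: 54.5%
Compound 3 `Cc1cccc(/C(N)=N/NC(=S)N2CCCC2)n1`: 79.2%

All three were tested in a functional assay on HeLa cells (Homo sapiens) for cytotoxicity, read by MTT assay, with a stated time of 72 h, tested at 10 uM; a lower number here means less inhibition of growth, a higher number more inhibition of growth at the concentration tested. Compound 3 stands highest of the three numbers; its nearest neighbour is compound 1, and compound 2 lies furthest from it, both gaps being beyond the scatter. Among the measured compounds shown here, the only one-place step among the measured pair is a number 1.8 percentage points lower from compound 1 to compound 2 (within the scatter), which swaps one saturated ring on the thiocarbonyl carbon for another and leaves the number essentially unchanged.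

Compound 4 `N/C(=N\NC(=S)N1CCCC1)c1ccccn1` has not yet been measured. It differs from compound 3 by hydrogen in place of methyl on an aromatic carbon, the carbon being an aromatic carbon of a six-membered aromatic ring with one nitrogen. For the measured compounds named here, no measured step removes this methyl, so the step from compound 1 to compound 2 bears on it only indirectly: it shows that a change on the other end of the shared core barely moves the number. Compound 4 otherwise shares the unsubstituted ring of compound 1 and compound 2 but carries the pyrrolidine of compound 3, so compound 4 is expected to fall between those two sets of numbers, at 64% within 48% to 80%, meaning an expected step of a number 15.2 percentage points lower from compound 3 to compound 4 (beyond the scatter), probably downward but uncertain.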

Compound 4, percent growth inhibition at one concentration: 63.5%
The estimate for compound 4 lay 0.5 percentage points above the measured number, within the range that was stated.
By their numbers in this assay, from the lowest: compounds 2, 1 and 4 (each within the scatter of the next); then compound 3.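

In this assay, among the compounds shown here, putting hydrogen in place of the methyl on the aromatic carbon next to the ring nitrogen gives a number 15.7 percentage points lower from compound 3 to compound 4 (beyond the scatter), so this is the first measured sign that this position affects growth inhibition. Changing the saturated ring on the thiocarbonyl carbon has no such clear effect, giving a number 9 percentage points higher from compound 2 to compound 4 (within the scatter) and a number 7.2 percentage points higher from compound 1 to compound 4 (within the scatter), so among these compounds the high number of compound 3 cannot be credited to pyrrolidin-1-yl alone and goes with the presence of the methyl. Nothing measured here gives a reason for the effect of the methyl.

From the compounds shown here alone, this reading rests on a single pair, so it remains open whether a methyl at the same carbon would raise the number in the same way alongside morpholin-4-yl or thiomorpholin-4-yl. Going by these compounds, it is also open whether an ethyl group, a methoxy group or a chlorine atom at that carbon would match the methyl, exceed it or lose the effect.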